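A few compounds are considered here, and "the series" means these few. Any claim that something is new, unique, unknown or untested is made for them only; others in the source may bear on it.

Measured compounds in a functional assay on MCF7 cells (Homo sapiens) for cytotoxicity, read by MTT assay, with a stated time of 48 h; on this read-out higher numbers stand for weaker inhibition and lower numbers for stronger inhibition:
compound 1 `O=C(CSc1nnc(-c2ccncc2)o1)N/N=C/c1ccccc1` gives 14600 nM
compound 2 `O=C(CSc1nnc(-c2ccncc2)o1)N/N=C/c1ccc(O)cc1` gives 11700 nM
compound 3 `O=C(CSc1nnc(-c2ccncc2)o1)N/N=C/c1ccccc1O` gives 4750 nM

Compound 2 holds the second highest number of the three. Against compound 1 it differs by a 1.2-fold lower number from compound 1 to compound 2 (0.10 log units; within the scatter), which is within the scatter; against compound 3 the step is a 2.5-fold lower number from compound 2 to compound 3 (0.39 log units; beyond the scatter), beyond it. Compound 1 to compound 3 gives a 3.1-fold lower number from compound 1 to compound 3 (0.49 log units; beyond the scatter).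

Compound 4 `O=C(CSc1nnc(-c2ccncc2)o1)N/N=C/C=C/c1ccccc1` is not yet measured. It differs from compound 2 by 2-phenylethenyl in place of 4-hydroxyphenyl on a carbon with a double bond to nitrogen. Going by the values given here, no measured step adds an ethenyl link; the only related step, a 1.2-fold lower number from compound 1 to compound 2 (0.10 log units; within the scatter), shows that the hydroxy on the 4-hydroxyphenyl barely moves this assay, so a plain phenyl carried on an ethenyl is expected to land near compound 1 and compound 2. The step of a 1.2-fold higher number from compound 2 to compound 4 (0.08 log units; within the scatter) is expected to stay within the scatter. Compound 4 is estimated at 14000 nM, range 6000 nM to 35000 nM.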

Compound 4, half-maximal inhibitory concentration: 10800 nM
The estimate for compound 4 lay 1.3-fold (0.11 log units) above the measured number; the range from low to high includes it.
By their numbers in this assay, from the lowest: compound 3; then compounds 4, 2 and 1 (each within the scatter of the next).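

In this assay the added ethenyl link leaves the number in place, with both (a 1.4-fold lower number from compound 1 to compound 4 (0.13 log units; within the scatter)) and (a 1.1-fold lower number from compound 2 to compound 4 (0.03 log units; within the scatter)) inside the scatter, so 2-phenylethenyl, phenyl and 4-hydroxyphenyl cannot be told apart on a carbon with a double bond to nitrogen. Only 2-hydroxyphenyl separates from 2-phenylethenyl (a 2.3-fold higher number from compound 3 to compound 4 (0.36 log units; beyond the scatter)). Nothing available explains this gap.

Still open, as far as these compounds go, is whether an amine or a methoxy in place of the hydroxy of 2-hydroxyphenyl would keep the lower number of compound 3. Also open, from the compounds shown here alone, is whether a longer chain than ethenyl would shift the number.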